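Swapping a Hydroxyphenyl Arm on a Shared Core

The source may hold more compounds than are shown below. What is called first, only, known or untested is meant among the compounds shown, and "the series" means these compounds.

In a functional assay on DU-145 cells (Homo sapiens) for inhibition (a higher number here means a weaker inhibitor, a lower number a stronger inhibitor), compound 1 `Oc1ccc(-c2cc(-c3cccc(F)c3)cc(-c3cccc(O)c3)n2)cc1` gives 2700 nM. Compound 2 `Oc1ccc(-c2cc(-c3cccc(C(F)(F)F)c3)cc(-c3cccc(O)c3)n2)cc1` gives 11100 nM in this assay, so that a 4.1-fold higher number from compound 1 to compound 2 (0.61 log units; beyond the scatter). For compound 3 `Oc1cccc(-c2cc(-c3cccc(OC(F)(F)F)c3)cc(-c3cccc(O)c3)n2)c1` the result is only a limit of the assay, > 50000 nM, as recorded under (the limit of > 50000 nM in this assay, at which 1 of the 3 values shown sits). Compound 3 therefore sits at the weak end of the numbers shown, without a number of its own. Compound 4 `Oc1ccc(-c2cc(-c3cccc(OC(F)(F)F)c3)cc(-c3cccc(O)c3)n2)cc1` differs from compound 3 by 4-hydroxyphenyl in place of 3-hydroxyphenyl on an aromatic carbon. Within the data shown here, no measured step shares this change; the only measured step, a 4.1-fold higher number from compound 1 to compound 2 (0.61 log units; beyond the scatter), concerns a different exchange and bears on it only indirectly, by showing the size a single change can reach in this assay. Compound 4 shares its arrangement of hydroxyphenyl groups with compound 2, which gives 11100 nM. A move from the limit towards a measurable number is expected for compound 4, estimated as an at least 2.5-fold lower number from compound 3 to compound 4 (0.39 log units; beyond the scatter). The estimate for compound 4 in this assay is 20000 nM, expected to lie between 6000 nM and 100000 nM.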

Compound 4, half-maximal inhibitory concentration: 5670 nM
Beside the measured number, compound 4's estimate is 3.5-fold (0.55 log units) above it; the whole stated range lies above it.
By their numbers in this assay, from the lowest: compound 1; then compounds 4 and 2 (each within the scatter of the next). At a limit, above all of these: compound 3.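

In this assay, the exchange of 4-hydroxyphenyl for 3-hydroxyphenyl on the carbon next to the ring nitrogen gives an at least 8.8-fold lower number from compound 3 to compound 4 (0.94 log units; beyond the scatter), which shows that, with trifluoromethoxy held fixed, the position of the hydroxyl on this arm separates a measurable number from a limit. The value of compound 3 is a limit of the assay and not a number: the limit of > 50000 nM in this assay, at which 1 of the 4 values shown sits. With the 4-hydroxyphenyl arm kept, trifluoromethoxy in place of trifluoromethyl gives a 2.0-fold lower number from compound 2 to compound 4 (0.29 log units; within the scatter), and trifluoromethoxy in place of fluoro gives a 2.1-fold higher number from compound 1 to compound 4 (0.32 log units; beyond the scatter), so trifluoromethoxy alone does not carry a compound to the limit.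

Going by these compounds, it remains open whether the exchange of arms has the same size with fluoro or trifluoromethyl in place of trifluoromethoxy. Also open, on these data alone, is how this assay reads with an amine or a methoxy group in place of the hydroxyl on the 4-hydroxyphenyl arm.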